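Swapping a thiophene for a pyridine on a shared biaryl core

This account rests on a few compounds, and the source may have more. Where it says the series, first, only, none or still open, it means among the compounds named here.

Measured compounds:
compound 1, `Oc1cccc(-c2cc(-c3cccnc3)nc(-c3cccc(Cl)c3)c2)c1`, "not determined" (no result reported)
compound 2, `Oc1ccc(-c2cc(-c3ccc(Cl)cc3)nc(-c3cccnc3)c2)cc1`, "not determined" (no result reported)
compound 3, `Oc1ccc(-c2cc(-c3cccc(Cl)c3)nc(-c3cccs3)c2)cc1`, 0%

Within the data shown here, compound 3 is the only member of this small set with a number in an assay on isolated protein for inhibition of DNA topoisomerase 1 (Homo sapiens), with a stated time of 30 min, tested at 20 uM; a higher number here means a stronger effect of the compound at the concentration tested, a lower number a weaker effect; compound 1 and compound 2 carry no result there, so compound 3 cannot be placed above or below any neighbour, and its own reading sits at the floor of the read-out. Compound 4, `Oc1ccc(-c2cc(-c3cccnc3)nc(-c3cccc(Cl)c3)c2)cc1`, is the next structure in line. Relative to compound 3 it changes in one place: pyridin-3-yl in place of thiophen-2-yl on an aromatic carbon. The thiophen-2-yl group leaves and a pyridin-3-yl group enters. Among the measured compounds shown here, with no steps between measured compounds to lean on, compound 4 is expected to give an inhibition close to that of compound 3, the step of a number 5 percentage points higher from compound 3 to compound 4 (within the scatter) estimated to be none beyond the scatter. Compound 4 is therefore estimated at 5%, within a range of 0% to 25%.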

Compound 4, a percentage reported as inhibition, at one concentration (the size of the read-out at that concentration, not a potency): 0%
For compound 4 the middle estimate is 5 percentage points above the measured one; low and high end bracket the measured number.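

In this assay, among these compounds, replacing thiophen-2-yl with pyridin-3-yl gives no change at the digits printed from compound 3 to compound 4 (within the scatter) and this is the first readable step at this position. Both readings lie at the floor of the read-out, so the step shows that neither group lifts inhibition at the concentration tested but cannot rank the two groups. Nothing available explains this flat result.

On these data alone, whether an amine or a carboxylic acid at this position would give any measurable inhibition remains open. So does whether any group here matters once a reading rises above the floor.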